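Aryl exchange on the azole nitrogen of compound 3

The source may hold more compounds than are shown below. What is called first, only, known or untested is meant among the compounds shown, and "the series" means these compounds.

Compound 1 `CCCCCc1ccc(C#Cc2c(-c3ccc(CCCCC)cc3)oc3nc(=O)n(Cc4cn(-c5ccccc5F)nn4)cc23)cc1` — in an ADME assay on WI-38 cells (Homo sapiens) for antiproliferative activity, read by MTT assay, with a stated time of 72 h (a lower number here means a stronger inhibitor, a higher number a weaker inhibitor), compound 1 gives 7340 nM.
Compound 2 `CCCCCCc1cc2cn(Cc3cn(-c4ccccc4F)nn3)c(=O)nc2o1` — compound 2 gives 69200 nM.
Compound 3 `O=c1nc2oc(CCCCl)cc2cn1Cc1cn(-c2ccccc2F)nn1` — compound 3 gives 76500 nM.

Compound 3 gives the highest of the three numbers; compound 2 sits within the scatter of it, while compound 1 lies well lower. Within the data shown here, the only measured step, a 1.1-fold higher number from compound 2 to compound 3 (0.04 log units; within the scatter), concerns the saturated chain and not the group on the aromatic nitrogen. Compound 4, `O=c1nc2oc(CCCCl)cc2cn1Cc1cn(-c2ccc(Cl)cc2)nn1`, differs from compound 3 by 4-chlorophenyl in place of 2-fluorophenyl on an aromatic nitrogen. Among the measured compounds shown here, no measured step touches such an exchange, so nothing here argues for a shift in either direction. Compound 4 is therefore expected to give 76500 nM, between 30000 nM and 200000 nM. The step from compound 3 is estimated as no change at the digits printed from compound 3 to compound 4 (within the scatter), none beyond the scatter.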

Compound 4, half-maximal inhibitory concentration: 72500 nM
Compound 4: the middle estimate sits 1.1-fold (0.02 log units) above what was measured; low and high end bracket the measured number.
By their numbers in this assay, from the lowest: compound 1; then compounds 2, 4 and 3 (each within the scatter of the next).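

In this assay, among these compounds, 4-chlorophenyl in place of 2-fluorophenyl on the aromatic nitrogen gives a 1.1-fold lower number from compound 3 to compound 4 (0.02 log units; within the scatter), the first evidence that concerns this position rather than the saturated chain. The exchange alters both the halogen and where it sits on the phenyl ring, yet the number stays within the scatter, so the two contributions cannot be separated. Nothing available explains this outcome. On these data alone, it remains open whether an amine or a carboxylic acid on this phenyl ring, or a longer chain in place of the ring, would move the number beyond the scatter.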